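The source may hold more compounds than are shown below. What is called first, only, known or untested is meant among the compounds shown, and "the series" means these compounds.

Of the compounds shown here, two that share one core have been tested in a functional assay on the whole organism (strain Wistar albino) for inhibition, with Rattus norvegicus as the target, read by paw edema, with a stated time of 3 h, at a dose of 25 mg/kg by the oral route; a lower number here means less inhibition, a higher number more inhibition at the dose given (going by the name of the read-out). Compound 1, `CSc1nn(-c2ccccc2)c2nc(Nc3ccccc3)n(-c3ccccc3)c(=O)c12`, gives 25.4% in this assay. Compound 2, `O=c1c2c(Nc3ccccc3)nn(-c3ccccc3)c2nc(Nc2ccccc2)n1-c1ccccc1`, gives 17.1% in this assay. Compound 2 stands lowest of the two numbers, yet its nearest neighbour, compound 1, sits within the scatter of it, so the two cannot be told apart. Within the data shown here, the single measured step, a number 8.3 percentage points lower from compound 1 to compound 2 (within the scatter), puts anilino in place of methylsulfanyl on an aromatic carbon and stays within the scatter.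

Compound 3, `O=c1c2c(Nc3ccc([N+](=O)[O-])cc3)nn(-c3ccccc3)c2nc(Nc2ccccc2)n1-c1ccccc1`, has not yet been measured. It differs from compound 2 by nitro in place of hydrogen on an aromatic carbon; read one bond further out, the anilino of compound 2 becomes (4-nitrophenyl)amino. Among the measured compounds shown here, no measured step bears on this change: the only step known, from compound 1 to compound 2, touched another place on the core, and neither measured compound carries a nitro group. With nothing pointing either way, the step is expected to stay within the scatter, that is a number 2.9 percentage points higher from compound 2 to compound 3 (within the scatter). Compound 3 is therefore estimated to give 20% in this assay, with a likely range from 8% to 35%.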

Compound 3, a percentage reported as inhibition, in the whole organism at one dose (the size of the read-out at that dose, not a potency): 15.1%
Compound 3: middle estimate off by 4.9 percentage points, on the high side, and the stated range covers the measured number.
By their numbers in this assay, from the lowest: compounds 3, 2 and 1 (each within the scatter of the next, the first and the last beyond it).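

Placing a nitro group on the anilino ring of compound 2 gives, in this assay, a number 2 percentage points lower from compound 2 to compound 3 (within the scatter) and so the change at this position, para to a large group, cannot be told apart from the usual spread of repeated measurements. Compared with the methylsulfanyl group of compound 1, the (4-nitrophenyl)amino group gives a number 10.3 percentage points lower from compound 1 to compound 3 (beyond the scatter) and this is the only step so far to pass the scatter, if only modestly, while the plain anilino group of compound 2 stays within the scatter of compound 1. Nothing measured alongside these numbers accounts for either step.

From the compounds shown here alone, a single substituent at a single spot on the anilino ring says little about that ring as a whole, so it remains open how an amine, a carboxylic acid or a methoxy group there would read in this assay. Going by these compounds, it is also open whether a longer chain on the sulfur, such as ethylsulfanyl in place of methylsulfanyl, would keep the number of compound 1 or move it further from those of compound 2 and compound 3.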